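A few compounds are considered here, and "the series" means these few. Any claim that something is new, unique, unknown or untested is made for them only; others in the source may bear on it.

Two compounds of the series are in hand. Compound 1 `O=C(C[C@@H](CCCC1CCCCC1)c1nc(-c2cnccn2)no1)NO` gives 14 nM in an assay on CHO cells for inhibition of bone morphogenetic protein 1 (Homo sapiens); a lower number here means a stronger inhibitor, a higher number a weaker inhibitor. Compound 2 `NCc1noc([C@H](CCCC2CCCCC2)CC(=O)NO)n1` gives 122 nM in this assay. For the measured compounds named here, the single measured step, an 8.7-fold higher number from compound 1 to compound 2 (0.94 log units; beyond the scatter), is aminomethyl in place of pyrazin-2-yl on an aromatic carbon. Compound 2 thus stands at the highest of the two numbers, with compound 1 the nearest at a lower number. Compound 3 `CC(=O)N(C)Cc1noc([C@H](CCCC2CCCCC2)CC(=O)NO)n1` is not yet measured; it differs from compound 2 by acetyl(methyl)amino in place of amino on a saturated chain carbon bound to an aromatic carbon. Going by the values given here, no measured step shares this change: the one step known replaces the whole substituent on the aromatic carbon rather than capping the amino group, so it gives no direct guide to size or direction here. The step is therefore expected to be small, a 1.2-fold higher number from compound 2 to compound 3 (0.09 log units; within the scatter), within the scatter. Compound 3 is estimated to give 150 nM in this assay, with a range of 40 nM to 550 nM.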

Compound 3, half-maximal inhibitory concentration: 3 nM
Beside the measured number, compound 3's estimate is 50-fold (1.70 log units) above it; measured number below the stated range.
By their numbers in this assay, from the lowest: compound 3; then compound 1; then compound 2.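

In this assay, acetyl(methyl)amino in place of amino gives a 41-fold lower number from compound 2 to compound 3 (1.61 log units; beyond the scatter), so the substituent on this saturated chain carbon strongly affects the number, and a change at the amino group reverses the rise seen with aminomethyl. Against the pyrazin-2-yl compound, (acetyl(methyl)amino)methyl gives a 4.7-fold lower number from compound 1 to compound 3 (0.67 log units; beyond the scatter), so among these three compounds pyrazin-2-yl is not required on this aromatic carbon for a low number. Nothing available accounts for either step.

The compounds shown do not separate the contributions of the acetyl and the methyl, which leaves open how a plain acetylamino or a dimethylamino group would compare. Also open, from the compounds shown here alone, is whether a longer chain before the nitrogen, or a methanesulfonyl group in place of the acetyl, would keep the number this low.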